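Compound 3 to compound 4: the amide-type nitrogen

This account rests on a few compounds, and the source may have more. Where it says the series, first, only, none or still open, it means among the compounds named here.

In a functional assay on cells (Platelet, Homo sapiens) for inhibition (a lower number here means a stronger inhibitor, a higher number a weaker inhibitor), compound 1 `O=C(O)c1ccc(-c2nn(Cc3ccccc3)c3ccccc23)cc1` reads only as a limit, > 10000 nM. Compound 2 `COC(=O)c1ccc(-c2nn(Cc3ccccc3)c3ccccc23)cc1` also reads only as a limit, > 10000 nM. Compound 3 `CNC(=O)c1ccc(-c2nn(Cc3ccccc3)c3ccccc23)cc1` stands at a limit too, > 10000 nM. Compound 4 `CC(C)NC(=O)c1ccc(-c2nn(Cc3ccccc3)c3ccccc23)cc1` has isopropyl in place of methyl on an amide-type nitrogen. The measured steps nearest this change are a step that the two limits leave unreadable from compound 1 to compound 3 and a step that the two limits leave unreadable from compound 2 to compound 3, with a step that the two limits leave unreadable from compound 1 to compound 2 as the remaining one. None has a readable size, and all three values share one ceiling: the limit of > 10000 nM in this assay, at which 3 of the 3 values shown sit. No direction can therefore be read in this assay, and the expected step is a step that the limit leaves unreadable from compound 3 to compound 4. For compound 4 the estimate is 12000 nM, with an expected range of 3000 nM to 40000 nM.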

Compound 4, half-maximal inhibitory concentration: > 10000 nM
Compound 4: no number, only a limit; the forecaster's own chance of this, stated with the estimate: 70%; the middle value lies beyond the limit too.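

No step can be read from compound 1, compound 2 or compound 3 to compound 4 in this assay, since all four compounds stop at one limit: the limit of > 10000 nM in this assay, at which 4 of the 4 values shown sit.

The compounds shown leave open whether any of these changes alters inhibition, and in which direction.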